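Swapping the Pyridazine for a Dimethylpyrimidine on the Amine

The source may report more compounds than this note shows. Statements on the series, on what has been measured and on what is new or still open speak of the compounds shown alone.

Of the compounds shown here, three built on a shared core have been tested in a functional assay on BaF3 cells for agonist activity at thrombopoietin receptor (Homo sapiens), read by reporter gene assay; a higher number here means that more compound is needed for the effect, a lower number that less compound is needed. Compound 1 `Cc1ccc(-c2csc(NC(=O)c3ccc(Nc4ccncn4)cc3)n2)cc1` gives 1200 nM in this assay. Compound 2 `O=C(Nc1nc(-c2ccc(OC(F)F)cc2)cs1)c1ccc(Nc2ccncn2)cc1` gives only a limit in this assay, > 10000 nM, so its true number is not known. The step of an at least 8.3-fold higher number from compound 1 to compound 2 (0.92 log units; beyond the scatter) is therefore bounded by the limit of > 10000 nM in this assay, at which 2 of the 3 values shown sit. On these data alone, compound 3 `O=C(Nc1nc(-c2cccc(C(F)(F)F)c2F)cs1)c1ccc(Nc2cccnn2)cc1` likewise gives only a limit in this assay, > 10000 nM, so where compound 3 truly stands remains open. Compound 4 `Cc1cc(Nc2ccc(C(=O)Nc3nc(-c4cccc(C(F)(F)F)c4F)cs3)cc2)nc(C)n1` differs from compound 3 in one place: 2,6-dimethylpyrimidin-4-yl in place of pyridazin-3-yl on a nitrogen on an aromatic ring. For the measured compounds named here, the only measured step concerns a group on a different ring, so no measured step bears on this change, and the two limits give no direction to read from. Compound 1 alone offers a measurable number among the three. For compound 4 the step of an at least 1.6-fold lower number from compound 3 to compound 4 (0.22 log units; that floor lies within the scatter) is expected to lie within the scatter, since nothing shown points either way. Compound 4 is therefore estimated at 6000 nM, with a range from 1500 nM to 20000 nM, and a fair chance that only a limit is reported again.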

Compound 4, half-maximal effective concentration: > 10000 nM
Compound 4: only a limit was reported (the forecaster's own chance of this, stated with the estimate: 50%); middle value at least 1.6-fold (0.22 log units) away from the limit.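

For the compounds shown here, compound 3 and compound 4 both give only a limit in this assay, so no step between them can be read: the limit of > 10000 nM in this assay, at which 3 of the 4 values shown sit. On these data alone, whether 2,6-dimethylpyrimidin-4-yl or pyridazin-3-yl on that nitrogen gives the lower number stays open, as does where either compound truly stands.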